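Cytotoxicity notes on the indole diketo ester series

The source may report more compounds than this note shows. Statements on the series, on what has been measured and on what is new or still open speak of the compounds shown alone.

Measured so far in an ADME assay on MT4 cells (Homo sapiens) for cytotoxicity, read by MTT assay; on this read-out higher numbers stand for lower toxicity in this test and lower numbers for higher toxicity in this test:
compound 1 `CCOC(=O)/C(O)=C/C(=O)c1cn(Cc2ccc(F)c(F)c2)c2cccc(OC)c12` gives 125000 nM;
compound 2 `CCOC(=O)/C(O)=C/C(=O)c1cn(Cc2c(F)cccc2F)c2cccc(OC)c12` gives 63400 nM.

Within the data shown here, compound 2 stands with compound 1 within the scatter, the only step recorded being a 2.0-fold lower number from compound 1 to compound 2 (0.29 log units; within the scatter). Compound 3 `CCOC(=O)/C(O)=C/C(=O)c1cn(Cc2ccccc2F)c2cccc(OC)c12` is not yet measured. Its change from compound 2 is hydrogen in place of fluoro on an aromatic carbon, on a saturated chain carbon bound to an aromatic nitrogen. Among the measured compounds shown here, only the single step from compound 1 to compound 2 bears on this, and that step stayed within the scatter, so no step beyond the scatter is expected in this assay : a 1.3-fold higher number from compound 2 to compound 3 (0.10 log units; within the scatter). Compound 3 is therefore estimated at 80000 nM, with a range from 35000 nM to 180000 nM.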

Compound 3, half-maximal cytotoxic concentration: 63300 nM
Beside the measured number, compound 3's estimate is 1.3-fold (0.10 log units) above it; the measured number falls inside the stated range.
By their numbers in this assay, from the lowest: compounds 3, 2 and 1 (each within the scatter of the next).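

In this assay, hydrogen in place of fluoro, taking 2,6-difluorobenzyl to 2-fluorobenzyl, gives a 1.0-fold lower number from compound 2 to compound 3 (0.00 log units; within the scatter) and so shows no readable change at this aromatic carbon. 2-Fluorophenyl in place of 3,4-difluorophenyl gives a 2.0-fold lower number from compound 1 to compound 3 (0.30 log units; within the scatter) and so leaves all three fluorinated patterns within the scatter of one another. Nothing at hand explains this flat read-out.

Still open, from the compounds shown here alone, is whether an amine or a carboxylic acid on this ring would move the number beyond the scatter. The same question stands for a longer chain in place of the benzyl carbon.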